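Notes on compound 4 against the shared core series

A few compounds are considered here, and "the series" means these few. Any claim that something is new, unique, unknown or untested is made for them only; others in the source may bear on it.

Compound 1 `Nc1cc(N)c2nc(-c3ccccc3)c(Oc3ccc(Cl)c(Cl)c3)nc2c1` carries a 3,4-dichlorophenoxy group on the shared core. In a functional assay on HCT-116 cells (Homo sapiens) for inhibition, read by sulforhodamine B assay, with a stated time of 48 h (on this read-out higher numbers stand for lower toxicity in this test and lower numbers for higher toxicity in this test), compound 1 gives < 100000 nM, which is a limit of the assay and not a number. Compound 2 `Nc1cc(N)c2nc(-c3ccccc3)c(NCc3ccc(F)cc3)nc2c1` has the (4-fluorobenzyl)amino group in its place. In this assay compound 2 also gives < 100000 nM, again a limit. Compound 3 `Nc1cc(N)c2nc(-c3ccccc3)c(Sc3ccc(Cl)c(Cl)c3)nc2c1` bears the (3,4-dichlorophenyl)sulfanyl group. In this assay compound 3 returns < 100000 nM, once more a limit. Because (the limit of < 100000 nM in this assay, at which 3 of the 3 values shown sit), none of the three compounds can be placed relative to one another, and compound 3 stands at the same limit as the other two.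

The measured steps are accordingly a step that the two limits leave unreadable from compound 1 to compound 2, a step that the two limits leave unreadable from compound 1 to compound 3 and a step that the two limits leave unreadable from compound 2 to compound 3. Compound 4 `Nc1cc(N)c2nc(-c3ccccc3)c(Oc3ccc(F)cc3)nc2c1` arises from compound 3 by 4-fluorophenoxy in place of (3,4-dichlorophenyl)sulfanyl on an aromatic carbon. Within the data shown here, the closest precedent is the change of 3,4-dichlorophenoxy to (3,4-dichlorophenyl)sulfanyl, which is unreadable, and the 4-fluoro substitution appears only on compound 2, also unreadable. No step size can therefore be derived, and the expectation is a step of no readable size in this assay.

Compound 4 is expected to give about 30000 nM in this assay, between 5000 nM and 100000 nM, a step that the limit leaves unreadable from compound 3 to compound 4 that is estimated rather than measured.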

Compound 4, concentration lethal to 50% of the cells: < 100000 nM
Compound 4 was reported as a limit; the forecaster's own chance of this, stated with the estimate: 50%; the middle value does not contradict the limit.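

No step from compound 1, compound 2 or compound 3 to compound 4 can be read in this assay, because all four compounds sit at one limit of the assay and not at a number: the limit of < 100000 nM in this assay, at which 4 of the 4 values shown sit.

The compounds shown leave open how the four groups on the shared core rank against one another in this assay.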